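This account rests on a few compounds, and the source may have more. Where it says the series, first, only, none or still open, it means among the compounds named here.

Measured compounds in a functional assay on HCT-116 cells (Homo sapiens) for inhibition, read by MTT assay, with a stated time of 2 days, tested at 10 uM; a lower number here means less inhibition, a higher number more inhibition at the concentration tested (going by the name of the read-out):

- compound 1, `COc1ccccc1-c1cn(-c2ccc(O)c(C(=O)Nc3cccc(C(F)(F)F)c3)c2)nn1`: 61%
- compound 2, `COc1ccccc1-c1cn(-c2ccc(O)c(C(=O)OCCCc3ccccc3)c2)nn1`: 7%
- compound 3, `COC(=O)c1cc(-n2cc(-c3ccccc3OC)nn2)ccc1O`: 8%

Compound 1 stands highest of the three numbers; the nearest is compound 3, the furthest compound 2, and both steps away from compound 1 lie beyond the scatter. The measured steps all change the group on the carbonyl carbon: a number 54 percentage points lower from compound 1 to compound 2 (beyond the scatter) and a number 53 percentage points lower from compound 1 to compound 3 (beyond the scatter), each large, while a number 1 percentage points higher from compound 2 to compound 3 (within the scatter) is within the scatter.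

Compound 4, `O=C(Nc1cccc(C(F)(F)F)c1)c1cc(-n2cc(-c3cccc(O)c3)nn2)ccc1O`, keeps the carbonyl group of compound 1 unchanged and differs only at the aromatic carbon of the triazole: 3-hydroxyphenyl in place of 2-methoxyphenyl on an aromatic carbon. Going by the values given here, no measured step touches that position, so the two large steps above say nothing about its size; the carbonyl amide that carries the high number of compound 1 is retained. The expectation is therefore a step of a number 9 percentage points lower from compound 1 to compound 4 (within the scatter), within or near the scatter, with no direction that the data can fix. Compound 4 is estimated at 52%, in the range 25% to 75%.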

Compound 4, a percentage reported as inhibition, at one concentration (the size of the read-out at that concentration, not a potency): 25%
Beside the measured number, compound 4's estimate is 27 percentage points above it; the range from low to high includes it.
By their numbers in this assay, from the lowest: compounds 2 and 3 (each within the scatter of the next); then compound 4; then compound 1.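

This position, on an aromatic carbon of a five-membered aromatic ring with 3 nitrogen, is not silent in this assay: 3-hydroxyphenyl in place of 2-methoxyphenyl gives a number 36 percentage points lower from compound 1 to compound 4 (beyond the scatter). Keeping the (3-(trifluoromethyl)phenyl)amino group on the carbonyl carbon therefore does not by itself hold the number of compound 1, which the steps at the carbonyl carbon alone could not show. No measurement bears on the cause of this step.

The single step changes the oxygen group and its place on the phenyl ring together, so the compounds shown do not separate the two. As far as these compounds go, whether the loss follows from the hydroxy group, from removing the methoxy group, or from both remains open, and a plain phenyl or an aminophenyl group at this position would help to settle it.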